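The source may report more compounds than this note shows. Statements on the series, on what has been measured and on what is new or still open speak of the compounds shown alone.

Measured so far:
compound 1 `CO[C@H]1CC[C@H](NC(=O)c2n[nH]cc2NC(=O)c2ccc(F)cc2F)CC1` — 11000 nM
compound 2 `COc1cccc(OC)c1C(=O)Nc1c[nH]nc1C(=O)NC1CCN(C(=O)OC(C)(C)C)CC1` — > 50000 nM
compound 3 `COc1cccc(OC)c1C(=O)Nc1c[nH]nc1C(=O)NCCN1CCCC1` — > 50000 nM

Going by the values given here, in an ADME assay on MRC5 cells (Homo sapiens) for inhibition, with a stated time of 72 h (on this read-out lower numbers stand for an effect already at smaller amounts and higher numbers for an effect only at larger amounts of compound), compound 1 gives 11000 nM, the only actual number in the set. Compound 2 reaches only a limit of the assay, > 50000 nM. Compound 3 likewise stops at a limit, > 50000 nM. Among the compounds with values here, the picture is therefore (the limit of > 50000 nM in this assay, at which 2 of the 3 values shown sit), with compound 1 the one compound below it. Within the data shown here, no step between measured compounds can be read from this set. Compound 4 `CO[C@H]1CC[C@H](NC(=O)c2n[nH]cc2NC(=O)c2cc(Cl)cc(Cl)c2)CC1` differs from compound 1 by 3,5-dichlorophenyl in place of 2,4-difluorophenyl on a carbonyl carbon. Among the measured compounds shown here, with no measured step to rest on, the expected step of a 1.4-fold lower number from compound 1 to compound 4 (0.14 log units; within the scatter) is small, not beyond the usual scatter. Compound 4 is expected to give 8000 nM in this assay, within 3000 nM to 30000 nM.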

Compound 4, half-maximal effective concentration: 13000 nM
Estimate against measurement, compound 4: 1.6-fold (0.21 log units) below; measured number inside the range.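

In this assay, 3,5-dichlorophenyl in place of 2,4-difluorophenyl on a carbonyl carbon gives a 1.2-fold higher number from compound 1 to compound 4 (0.07 log units; within the scatter), the first step readable at this position. This pair of halogen-bearing phenyl groups therefore cannot be told apart on this read-out. No measured property offers a cause for this result.

From the compounds shown here alone, whether a phenyl ring carrying an amine or a carboxylic acid at this place would move the number beyond the scatter remains open. So does the effect of changes on the other side of the shared core.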